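The compounds below may be only part of what the source reports. "The series", "measured", "known", "first", "only" and "open" are said of these compounds alone.

Compound 1, `COc1cc(OC)c(OC)cc1/C=C/C(=O)c1cc(Cc2ccccc2)cc(Cc2ccccc2)c1`, gives 69900 nM in a functional assay on SW982 cells (Homo sapiens) for inhibition, read by MTT assay, with a stated time of 72 h; on this read-out higher numbers stand for weaker inhibition and lower numbers for stronger inhibition.
Compound 2, `COc1cc(OC)c(-c2cc(=O)c3cc(O)ccc3o2)cc1OC`, gives only a limit in this assay, > 150000 nM, so no number is known for it.
Compound 3, `COc1cc(OC)c(OC)cc1/C=C/C(=O)c1ccc(O)cc1O`, gives 32400 nM in this assay.

Among the two compounds that give a number, compound 3 has the lowest half-maximal inhibitory concentration, that is the stronger inhibition; the nearest number is that of compound 1, which sits above it by a gap beyond the usual scatter. Compound 2 gives no number at all, only a limit, as one of three values here does (the limit of > 150000 nM in this assay, at which 1 of the 3 values shown sits).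

Compound 4, `COc1cc(OC)c(OC)cc1/C=C/C(=O)c1ccccc1`, has not yet been measured. It differs from compound 3 in one place: phenyl in place of 2,4-dihydroxyphenyl on a carbonyl carbon. The two groups that leave carry the only hydrogen-bond donors of the ring that is replaced. Among the compounds with values here, with no measured step of this kind among the compounds here, the size of the change is uncertain, but a weaker inhibition, a step upward in this assay, seems more likely than a stronger one. The number for compound 4 is therefore estimated at 70000 nM, within 25000 nM to 150000 nM, which would mean the step of a 2.2-fold higher number from compound 3 to compound 4 (0.33 log units; beyond the scatter) is expected.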

Compound 4, half-maximal inhibitory concentration: > 150000 nM
Compound 4 ended at the assay's limit; the forecaster's own chance of this, stated with the estimate: 25%; at least 2.1-fold (0.33 log units) between middle value and limit.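

Within the data shown here, this is the first measured step at the ring on the carbonyl carbon, and it shows that the change matters: phenyl in place of 2,4-dihydroxyphenyl gives an at least 4.6-fold higher number from compound 3 to compound 4 (0.66 log units; beyond the scatter) in this assay. An aromatic ring of carbon stays in place, so what differs is the loss of the hydroxy groups, which carry the only hydrogen-bond donors of that ring. Compound 4 reads only as a limit, so the step has a lower bound and no known upper end: the limit of > 150000 nM in this assay, at which 2 of the 4 values shown sit.

The compounds shown cannot tell whether a single hydroxy group on that ring would be enough to keep the inhibition of compound 3, or whether both are needed. They also leave open how a methoxy group or an amine in place of those hydroxy groups would compare.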